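Swapping the halogenated aryl amide toward a 3-chlorophenyl

This account rests on a few compounds, and the source may have more. Where it says the series, first, only, none or still open, it means among the compounds named here.

Measured compounds:
- Compound 1, `COc1ccc(C(=O)Nc2cc(Br)cc(C(F)(F)F)c2)cc1Nc1nccc(-c2cccnc2)n1`: 215000 nM
- Compound 2, `COc1ccc(C(=O)Nc2ccc(Br)cc2)cc1Nc1nccc(-c2cccnc2)n1`: "not determined" (no result reported)

These compounds share a core, seen in compound 1 and compound 2, that differs only in the aryl group on the amide nitrogen. In a functional assay on K562 cells (Homo sapiens) for antiproliferative activity, read by MTT assay, with a stated time of 48 h (on this read-out higher numbers stand for weaker inhibition and lower numbers for stronger inhibition), compound 1 gives 215000 nM, a weak result. For compound 2 no number exists in this assay, so it stands nowhere on the scale; only its structure is known.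

Compound 3, `COc1ccc(C(=O)Nc2cccc(Cl)c2)cc1Nc1nccc(-c2cccnc2)n1`, is the next step. It differs from compound 2 by 3-chlorophenyl in place of 4-bromophenyl on an amide-type nitrogen. With no value for compound 2, the size and direction of this step cannot be read from anything shown; the only anchor is the weak value of compound 1, which carries a related halogenated aryl amide.

Compound 3 is therefore expected to sit in a similarly weak region, estimated at 120000 nM with a plausible range from 20000 nM to 500000 nM.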

Compound 3, half-maximal inhibitory concentration: 237000 nM
The estimate for compound 3 lay 2.0-fold (0.30 log units) below the measured number; the range from low to high includes it.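

In this assay, within the data shown here, the first readable comparison at this position comes from putting 3-chlorophenyl in place of 3-bromo-5-(trifluoromethyl)phenyl on the amide-type nitrogen, which gives a 1.1-fold higher number from compound 1 to compound 3 (0.04 log units; within the scatter) for this pair. Compound 1 and compound 3 therefore cannot be told apart, even though their aryl groups differ in the halogen and in the trifluoromethyl group, and both numbers remain weak. No measurement shown here explains this result.

As far as these compounds go, the step from compound 2 to compound 3 cannot be read, so the effect of replacing 4-bromophenyl with 3-chlorophenyl remains unknown. Also open, from the compounds shown here alone, is whether a phenyl carrying an amine or a carboxylic acid on this amide nitrogen would give a stronger result in this assay than the halogenated aryl groups do.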